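This account rests on a few compounds, and the source may have more. Where it says the series, first, only, none or still open, it means among the compounds named here.

In a functional assay on SH-SY5Y cells (Homo sapiens) for antagonist activity, read by cAMP accumulation (on this read-out lower numbers stand for lower potency and higher numbers for higher potency (the scale is a negative logarithm)), compound 2 `OCCOc1ccc(Cc2ccc(NC3=NCCN3)cc2)cc1` gives 8 and compound 1 `c1ccc(COc2ccc(Cc3ccc(NC4=NCCN4)cc3)cc2)cc1` gives 7.7, so the two numbers lie within the scatter of each other. Compound 3 `c1cc(NC2=NCCN2)ccc1Cc1ccc(OC2CCOCC2)cc1` differs from compound 2 by oxan-4-yl in place of 2-hydroxyethyl on an oxygen on an aromatic ring, with oxan-4-yl in place of 2-hydroxyethyl on an oxygen on an aromatic ring. For the measured compounds named here, the only measured step at this oxygen is a number 0.30 log units higher from compound 1 to compound 2 (within the scatter), and no measured step involves oxan-4-yl. A change beyond the scatter is therefore not expected in this assay. The estimated step is no change at the digits printed from compound 2 to compound 3 (within the scatter). For compound 3, the expected value is 8, with an estimated range from 7.5 to 8.5.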

Compound 3, negative logarithm of the antagonist equilibrium constant: 8.4
Estimate against measurement, compound 3: 0.40 log units below; measured number inside the range.
By their numbers in this assay, from the lowest: compounds 1 and 2 (each within the scatter of the next); then compound 3.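

In this assay, the oxygen on an aromatic ring now shows steps beyond the scatter: a number 0.40 log units higher from compound 2 to compound 3 (beyond the scatter) with oxan-4-yl in place of 2-hydroxyethyl, and a number 0.70 log units higher from compound 1 to compound 3 (beyond the scatter) with oxan-4-yl in place of benzyl. The earlier step at this oxygen lay within the scatter, so the substituent here can shift the number measurably. A hydroxyl-free six-membered ring also stands above both open-chain or benzyl ethers, and no supporting measurement accounts for the gain. Open, going by these compounds, is whether the ring oxygen of oxan-4-yl matters, which cyclohexyl would test. A piperidin-4-yl amine at this oxygen also remains to be placed.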